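Anilino group changes on a shared core: antiproliferative notes

The compounds below may be only part of what the source reports. "The series", "measured", "known", "first", "only" and "open" are said of these compounds alone.

Measured so far:
compound 1, `CN(c1cccc2c1CN(c1nc(Nc3ccc(C(F)(F)F)cc3)ncc1C(F)(F)F)C2)S(C)(=O)=O`: > 30000 nM
compound 2, `COc1cc(Nc2ncc(C(F)(F)F)c(N3Cc4cccc(N(C)S(C)(=O)=O)c4C3)n2)cc(OC)c1`: 1800 nM
compound 3, `COc1cc(Nc2ncc(C(F)(F)F)c(N3Cc4cccc(N(C)S(C)(=O)=O)c4C3)n2)cc(C(F)(F)F)c1`: 22100 nM

In a functional assay on HepG2 cells (Homo sapiens) for antiproliferative activity, read by spectrophotometry, with a stated time of 2 days (on this read-out lower numbers stand for stronger inhibition of growth and higher numbers for weaker inhibition of growth), compound 1 gives only a limit, > 30000 nM. Compound 4, `Cc1ccc(Nc2ncc(C(F)(F)F)c(N3Cc4cccc(N(C)S(C)(=O)=O)c4C3)n2)c(C)c1`, differs from compound 1 at the anilino ring: 2,4-dimethylphenyl in place of 4-(trifluoromethyl)phenyl on a nitrogen on an aromatic ring. The measured steps from compound 1 that bear on this are an at least 16-fold lower number from compound 1 to compound 2 (1.22 log units; beyond the scatter) and an at least 1.3-fold lower number from compound 1 to compound 3 (0.13 log units; that floor lies within the scatter); the second rests on the limit (the limit of > 30000 nM in this assay, at which 1 of the 3 values shown sits). Within the methoxy pair, a 12-fold higher number from compound 2 to compound 3 (1.09 log units; beyond the scatter). Neither step covers a 2,4-dimethylphenyl group, so the expectation is uncertain: a moderate drop is estimated, an at least 3.3-fold lower number from compound 1 to compound 4 (0.52 log units; beyond the scatter), with a real chance that the limit is reported again. Compound 4 is thus expected near 9000 nM, between 2500 nM and 30000 nM.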

Compound 4, concentration for 50% growth inhibition: 19100 nM
The estimate for compound 4 lay 2.1-fold (0.33 log units) below the measured number; the measured number falls inside the stated range.
By their numbers in this assay, from the lowest: compound 2; then compounds 4 and 3 (each within the scatter of the next). At a limit, above all of these: compound 1.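

In this assay a ring without trifluoromethyl on the anilino nitrogen still falls well short of the 3,5-dimethoxyphenyl group, with an 11-fold higher number from compound 2 to compound 4 (1.03 log units; beyond the scatter). The 2,4-dimethylphenyl group and the 3-methoxy-5-(trifluoromethyl)phenyl group cannot be told apart, with a 1.2-fold lower number from compound 3 to compound 4 (0.06 log units; within the scatter). Compound 1 stands at a limit, so an at least 1.5-fold lower number from compound 1 to compound 4 (0.19 log units; that floor lies within the scatter) is only a floor: the limit of > 30000 nM in this assay, at which 1 of the 4 values shown sits.

Still open, going by these compounds, is whether 3,5-dimethylphenyl would track compound 2 or compound 4. Also open, on these data alone, is how a morpholine or a carboxylic acid on the anilino ring would compare with the 3,5-dimethoxyphenyl group.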